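Aryl in place of cyclohexyl: expected gain in half-life

A few compounds are considered here, and "the series" means these few. Any claim that something is new, unique, unknown or untested is made for them only; others in the source may bear on it.

Compound 1 `CCc1nc2cc(Cl)ccn2c1C(=O)NCc1ccc2oc(C3CCCCC3)nc2c1` gives 0.158 h in an ADME assay on microsomes from liver (Rattus norvegicus) for metabolic stability; a lower number here means that the compound disappears faster, a higher number that the compound lasts longer. Compound 3 `CCc1nc2ccc(Cl)cn2c1C(=O)NCc1ccc2ccccc2c1` gives 0.0517 h in this assay, so of the two numbers shown, compound 1 stands higher. Compound 2 `CCc1nc2cc(Cl)ccn2c1C(=O)NCc1ccc2oc(-c3ccc(OC(F)(F)F)cc3)nc2c1` returns only a limit of this assay, > 2 h, and no number. Compound 4 `CCc1nc2cc(Cl)ccn2c1C(=O)NCc1ccc2oc(-c3ccc(F)cc3)nc2c1` has not yet been measured in this assay; it differs from compound 1 by 4-fluorophenyl in place of cyclohexyl on an aromatic carbon. Among the measured compounds shown here, one measured step bears on this change: an at least 12-fold higher number from compound 1 to compound 2 (1.10 log units; beyond the scatter), in which 4-(trifluoromethoxy)phenyl replaced cyclohexyl at the same place and the number reached (the limit of > 2 h in this assay, at which 1 of the 3 values shown sits). Compound 4 carries a different six-membered aromatic ring at that place, so a rise of the same direction is expected in this assay, though its size is uncertain and it may again end at the limit. For compound 4 the expected step from the cyclohexyl parent is a 7.6-fold higher number from compound 1 to compound 4 (0.88 log units; beyond the scatter). Compound 4 is estimated at 1.2 h in this assay, with a range from 0.4 h to 2.5 h.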

Compound 4, half-life: > 2 h
Compound 4 ended at the assay's limit (the forecaster's own chance of this, stated with the estimate: 35%); middle value at least 1.6-fold (0.22 log units) away from the limit.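

In this assay, the gain at this place, on the aromatic carbon next to the ring nitrogen and next to the ring oxygen, no longer rests on a single aryl group: 4-fluorophenyl in place of cyclohexyl gives an at least 12-fold higher number from compound 1 to compound 4 (1.10 log units; beyond the scatter). Compound 2 and compound 4 both return limits and not numbers, so the step between them cannot be read, and fluoro and trifluoromethoxy cannot be ranked here. The two aryl compounds now share the same ceiling: the limit of > 2 h in this assay, at which 2 of the 4 values shown sit.

As far as these compounds go, how far either aryl compound lies past that limit stays open. Also open, from the compounds shown here alone, is whether unsubstituted phenyl or a saturated ring carrying nitrogen, such as piperidinyl, would behave like the two aryl groups or like cyclohexyl at this place.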